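A few compounds are considered here, and "the series" means these few. Any claim that something is new, unique, unknown or untested is made for them only; others in the source may bear on it.

Measured so far:
compound 1, `O=C1NCCN1c1ccc(S(=O)(=O)Nc2ccc(C3CCCCC3)cc2)cc1`: > 1000 nM
compound 2, `O=C1NCCN1c1ccc(S(=O)(=O)Nc2cccc(Oc3ccccc3)c2)cc1`: 220 nM
compound 3, `CC(C)(C)c1cc(NS(=O)(=O)c2ccc(N3CCNC3=O)cc2)cc(C(C)(C)C)c1`: > 1000 nM

All three were tested in a functional assay on MCF7 cells (Homo sapiens) for antiproliferative activity, read by sulforhodamine B assay, with a stated time of 48 h; a higher number here means a weaker inhibitor, a lower number a stronger inhibitor. Compound 1 gives > 1000 nM, which is a limit of the assay rather than a measured number. Compound 3 also gives a limit, > 1000 nM. For the measured compounds named here, compound 2 is the only one with a measured number and gives 220 nM. So compound 1 stands at the limit of > 1000 nM in this assay, at which 2 of the 3 values shown sit; it cannot be ranked against compound 3, and the two values only show that compound 2 sits inside the measurable range while compound 1 does not.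

Compound 4, `Cc1ccc(NS(=O)(=O)c2ccc(N3CCNC3=O)cc2)cc1`, has not yet been measured in this assay. It differs from compound 1 in one place: methyl in place of cyclohexyl on an aromatic carbon. Going by the values given here, no step between two measured compounds is available to guide the expectation, since none of the measured compounds differ from each other in a single place. Among the compounds with values here, the small group entering in compound 4 has no counterpart among the measured compounds, so the expectation rests on compound 1 alone. Compound 4 is expected to remain weak, with the estimated step from compound 1 to compound 4 being a step that the limit leaves unreadable from compound 1 to compound 4, that is, no change beyond the scatter. The estimate for compound 4 is 1500 nM, in a range from 300 nM to 8000 nM.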

Compound 4, half-maximal inhibitory concentration: 610 nM
Beside the measured number, compound 4's estimate is 2.5-fold (0.39 log units) above it; measured number inside the range.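

In this assay compound 4 gives 610 nM, so with methyl in place of cyclohexyl on this aromatic carbon, the cyclohexyl ring is not required for a number inside the measurable range. Compound 1 gives > 1000 nM, which is a limit of the assay and not a number. The change can be read only as a floor, an at least 1.6-fold lower number from compound 1 to compound 4 (0.21 log units; that floor lies within the scatter), and its true size stays unknown because compound 1 sits at a limit and not at a measured number: the limit of > 1000 nM in this assay, at which 2 of the 4 values shown sit.

Only cyclohexyl and methyl are shown at this aromatic carbon, and one of the two carries a limit, leaving open whether the number follows the size of the group at all. Also open, from the compounds shown here alone, is how a plain hydrogen, an isopropyl group, a longer carbon chain, an amine or a carboxylic acid at the same carbon would read in this assay, and those groups would show whether methyl is a special case or one point on a wider trend.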